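Trifluoromethyl on the aromatic ring of compound 2

The source may hold more compounds than are shown below. What is called first, only, known or untested is meant among the compounds shown, and "the series" means these compounds.

Among the compounds with values here, in a functional assay on LoVo cells (Homo sapiens) for inhibition, read by colorimetric assay and MTT assay, with a stated time of 72 h (a lower number here means a stronger inhibitor, a higher number a weaker inhibitor), compound 1 `CCCCOc1ncc(-c2ccccc2OC)n1C` gives 39000 nM, and compound 2 `C=CCCCCOc1ncc(-c2ccccc2OC)n1C` gives 4000 nM, the lowest of the three numbers so far. Compound 3 `C=CCCCCOc1ncc(-c2ccc(Cl)cc2OC)n1C` gives 35000 nM. Compound 4 `C=CCCCCOc1ncc(-c2cc(C(F)(F)F)ccc2OC)n1C` has trifluoromethyl in place of hydrogen on an aromatic carbon of compound 2: trifluoromethyl in place of hydrogen on an aromatic carbon. The chain change, a 9.8-fold lower number from compound 1 to compound 2 (0.99 log units; beyond the scatter), does not bear on this. The nearest guide is chloro in place of hydrogen on an aromatic carbon in compound 3, which gave an 8.8-fold higher number from compound 2 to compound 3 (0.94 log units; beyond the scatter). Within the data shown here, no measured compound carries trifluoromethyl, so the guide is loose. A similar or somewhat smaller rise is expected, an estimated 3.8-fold higher number from compound 2 to compound 4 (0.57 log units; beyond the scatter). Compound 4 is expected at 15000 nM, within an estimated range of 4000 nM to 50000 nM.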

Compound 4, half-maximal inhibitory concentration: 51000 nM
Compound 4: the middle estimate sits 3.4-fold (0.53 log units) below what was measured; measured number outside the range, above it.
By their numbers in this assay, from the lowest: compound 2; then compounds 3, 1 and 4 (each within the scatter of the next).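

In this assay, trifluoromethyl on the aromatic carbon para to a methoxy group takes compound 2 to a clearly higher number, with a 13-fold higher number from compound 2 to compound 4 (1.11 log units; beyond the scatter) as the step. Together with the chloro step (an 8.8-fold higher number from compound 2 to compound 3 (0.94 log units; beyond the scatter)), this means both ring additions shown raise the number, and neither goes against that pattern. Nothing available explains the rise at this position. Going by these compounds, whether fluoro, methyl or an amine at this same carbon would keep the number near that of compound 2 remains open.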